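One side chain swapped on a propylsulfanyl compound

The source may hold more compounds than are shown below. What is called first, only, known or untested is meant among the compounds shown, and "the series" means these compounds.

Compound 1 (`CCCSC(=O)COC(=O)C1=C2C(=NC1=O)c1cccc3cccc2c13`) gives 10100 nM in a functional assay on BXPC-3 cells (Homo sapiens) for antiproliferative activity, read by sulforhodamine B assay, with a stated time of 72 h; a lower number here means a stronger inhibitor, a higher number a weaker inhibitor
Compound 2 (`CCCSc1ccc2c3c(cccc13)C1=NC(=O)C(C(=O)OCC)=C12`) gives 5800 nM in this assay
Compound 3 (`O=C(COC(=O)C1=C2C(=NC1=O)c1cccc3cccc2c13)OCC(F)(F)C(F)(F)F`) gives 23300 nM in this assay

Compound 2 and compound 1 lie within the usual scatter of each other, so neither can be ranked above the other. Compound 3 stands beyond the scatter from compound 2, with the higher number.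

Compound 4 (`CCCSC(=O)COC(=O)C1=C2C(=NC1=O)c1cccc3c(SCCC)ccc2c13`) has not yet been measured. The change from compound 2 to compound 4 is (propylsulfanyl)carbonyl in place of methyl on a saturated chain carbon bound to an oxygen next to a carbonyl group and, cut one bond further out, it reads ethoxy to ((propylsulfanyl)carbonyl)methoxy.

Among the compounds with values here, only one measured step concerns this side chain, namely a 2.3-fold higher number from compound 1 to compound 3 (0.36 log units; beyond the scatter) for pentafluoropropoxy in place of propylsulfanyl on a carbonyl carbon. That step was modest, and it does not test the change made here. The side chain of compound 4 also stands on compound 1, which has no propylsulfanyl group on the core. Compound 1 gives 10100 nM and stays within the scatter of compound 2. Within the data shown here, no measured pair shows this change on its own, so no step beyond the scatter is expected in this assay, though a slight rise is possible. The estimate amounts to a 1.3-fold higher number from compound 2 to compound 4 (0.11 log units; within the scatter) as the expected move. For compound 4 the expected value is 7500 nM with an estimated range from 3000 nM to 18000 nM when measured.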

Compound 4, half-maximal inhibitory concentration: 56300 nM
Estimate against measurement, compound 4: 7.5-fold (0.88 log units) below, and the stated range ends below it.
By their numbers in this assay, from the lowest: compounds 2 and 1 (each within the scatter of the next); then compound 3; then compound 4.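

In this assay, placing (propylsulfanyl)carbonyl in place of methyl on a saturated chain carbon bound to an oxygen next to a carbonyl group gives a 9.7-fold higher number from compound 2 to compound 4 (0.99 log units; beyond the scatter), so this longer side chain is far from a neutral swap on a core that already carries a propylsulfanyl group. Approaching compound 4 from the other side, propylsulfanyl in place of hydrogen on an aromatic carbon gives a 5.6-fold higher number from compound 1 to compound 4 (0.75 log units; beyond the scatter), which means that each of the two groups raises the number when the other is already present. Nothing available explains why these two groups fare so poorly together.

The compounds shown leave open whether propylsulfanyl on the aromatic carbon also raises the number when the side chain is the plain ethoxy ester of compound 2, since the matching compound with hydrogen at that carbon is not among them. They also leave open how a carboxylic acid in place of the ester, or an amine in place of propylsulfanyl on the aromatic carbon, would behave in this assay.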